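A few compounds are considered here, and "the series" means these few. Any claim that something is new, unique, unknown or untested is made for them only; others in the source may bear on it.

Working notes on the series.

Compound 1 `O=C(CCCCCCc1ccc(F)cc1)N1CCCC1` gives 8000 nM in an assay on HEK293 cells for inhibition of N-acylethanolamine-hydrolyzing acid amidase (Rattus norvegicus), read by LC-MS, with a stated time of 30 min; on this read-out higher numbers stand for weaker inhibition and lower numbers for stronger inhibition. Among the measured compounds shown here, compound 2 `O=C(CCCCCCc1ccc(Cl)cc1)N1CCCC1` gives 34500 nM in this assay, the highest of the two numbers so far; the step of a 4.3-fold higher number from compound 1 to compound 2 (0.63 log units; beyond the scatter) sets compound 2 apart from compound 1.

The next step leads to compound 3 `COC(=O)c1ccc(CCCCCCC(=O)N2CCCC2)cc1`, in which the change is methoxycarbonyl in place of chloro on an aromatic carbon. For the measured compounds named here, the only measured step on the same aromatic carbon, a 4.3-fold higher number from compound 1 to compound 2 (0.63 log units; beyond the scatter), swaps one halogen for another and so bears only loosely on an ester entering in place of a halogen. It shows that substitution at that carbon can move this assay by a modest amount, but gives no direction for the present change. A step of moderate size in either direction is therefore plausible, and the expected step of a 1.7-fold lower number from compound 2 to compound 3 (0.24 log units; within the scatter) is set close to no change. Compound 3 is estimated at 20000 nM in this assay, within 5000 nM to 80000 nM.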

Compound 3, half-maximal inhibitory concentration: > 100000 nM
Compound 3 gave a limit, no number; the forecaster's own chance of this, stated with the estimate: 20%; middle value at least 5.0-fold (0.69 log units) from the limit.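

Compound 3 gives no number in this assay, only a limit: the limit of > 100000 nM in this assay, at which 1 of the 3 values shown sits. Methoxycarbonyl in place of chloro gives an at least 2.8-fold higher number from compound 2 to compound 3 (0.46 log units; beyond the scatter), and methoxycarbonyl in place of fluoro gives an at least 12-fold higher number from compound 1 to compound 3 (1.09 log units; beyond the scatter), so the larger group on this aromatic carbon moves the read-out towards weaker inhibition, not merely within the modest range seen between the two halogens. Across the three compounds the order of inhibition runs from fluoro through chloro to methoxycarbonyl, with no compound going against it, and this position is now shown to be able to lose most of the measurable inhibition through a single change.

As far as these compounds go, how far compound 3 lies past its limit stays open, so the true size of both steps is unknown. From the compounds shown here alone, whether a carboxylic acid, an amine or a methyl group on the same aromatic carbon would read nearer to fluoro or to methoxycarbonyl also stays open.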